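From furan-2-yl to ethynyl on a shared core

The source may hold more compounds than are shown below. What is called first, only, known or untested is meant among the compounds shown, and "the series" means these compounds.

Of the compounds shown here, two with the same sugar-bearing core have been tested in a functional assay on K562 cells (Homo sapiens), read by MTT assay, with a stated time of 72 h; on this read-out higher numbers stand for weaker inhibition and lower numbers for stronger inhibition. Compound 1 `CSc1ncnc2c1c(-c1ccccc1)cn2[C@@H]1O[C@H](CO)[C@@H](O)[C@H]1O` gives > 20000 nM, which is a limit of the assay and not a number. Among the measured compounds shown here, compound 2 `CNc1ncnc2c1c(-c1ccco1)cn2[C@@H]1O[C@H](CO)[C@@H](O)[C@H]1O` gives 220 nM, the only actual number so far. Compound 3 `C#Cc1cn([C@@H]2O[C@H](CO)[C@@H](O)[C@H]2O)c2ncnc(NC)c12` has ethynyl in place of furan-2-yl on an aromatic carbon. For the measured compounds named here, no measured step bears on this change, so no shift beyond the scatter is expected in this assay. The estimated change is a 1.5-fold lower number from compound 2 to compound 3 (0.17 log units; within the scatter). Compound 3 is expected to give 150 nM. The estimated range for compound 3 runs from 20 nM to 2000 nM.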

Compound 3, half-maximal inhibitory concentration: > 20000 nM
Compound 3: only a limit was reported; the forecaster's own chance of this, stated with the estimate: 8%; middle value at least 130-fold (2.12 log units) from the limit.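

In this assay, this position on the shared core tolerates no free exchange: ethynyl in place of furan-2-yl on an aromatic carbon gives an at least 90-fold higher number from compound 2 to compound 3 (1.95 log units; beyond the scatter). Compound 3 gives > 20000 nM, which is a limit of the assay and not a number. The step therefore marks only the smallest possible gap, and its true size cannot be read: the limit of > 20000 nM in this assay, at which 2 of the 3 values shown sit.

The compounds shown leave open whether a thiophen-2-yl ring or a propyl chain at this position would retain activity. Compound 1 differs from compound 2 in more than one place, so it cannot settle what its phenyl group does here.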